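The source may hold more compounds than are shown below. What is called first, only, known or untested is meant among the compounds shown, and "the series" means these compounds.

In an assay for inhibition of Indoleamine 2,3-dioxygenase 1 (Homo sapiens), with stated times of 10 min and 60 min, tested at 100 uM (a lower number here means a weaker effect, a higher number a stronger effect of the compound at the concentration tested), three compounds have been measured so far:

Compound 1, `FC(F)(F)c1cc(NC[C@H]2CCCN2)c2cn[nH]c2c1`, gives 83%.
Compound 2, `O=[N+]([O-])c1ccccc1CNc1cccc2[nH]ncc12`, gives 65%.
Compound 3, `O=[N+]([O-])c1ccc(Cl)cc1CNc1cc(C(F)(F)F)cc2[nH]ncc12`, gives 65%.

Compound 1 stands highest of the three numbers. Its nearest neighbour is compound 2, whose inhibition is lower by an amount beyond the usual scatter, and the same gap separates it from compound 3; compounds 2 and 3 themselves show the same number. No pair of these compounds differs in a single place, so no step can be read from them directly.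

Compound 4, `Nc1cccc(CNc2cc(C(F)(F)F)cc3[nH]ncc23)c1`, has not yet been measured. It departs from compound 1 in one place: 3-aminophenyl in place of pyrrolidin-2-yl on a saturated chain carbon bound to a nitrogen on an aromatic ring. Compound 4 shares the trifluoromethyl-bearing core with compound 1 and compound 3, and carries, like compounds 2 and 3, an aryl-bearing chain rather than the pyrrolidin-2-yl of compound 1.

Since compound 2 gives 65% and compound 3 gives 65%, both with aryl groups on that chain carbon, a downward step from compound 1 to compound 4, beyond the scatter, is expected. The estimated step is a number 18 percentage points lower from compound 1 to compound 4 (beyond the scatter). Compound 4 is therefore expected to give about 65%, estimated within a range from 45% to 83%.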

Compound 4, a percentage reported as inhibition, at one concentration (the size of the read-out at that concentration, not a potency): 55%
For compound 4 the middle estimate is 10 percentage points above the measured one; measured number inside the range.
By their numbers in this assay, from the lowest: compounds 4, 2 and 3 (each within the scatter of the next); then compound 1.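

In this assay, the saturated chain carbon bound to a nitrogen on an aromatic ring now has its first direct comparison: 3-aminophenyl in place of pyrrolidin-2-yl gives a number 28 percentage points lower from compound 1 to compound 4 (beyond the scatter) on the shared core. This change replaces a five-membered non-aromatic ring carrying a defined stereocentre with a six-membered aromatic ring of carbon only, while the hydrogen-bond donor and acceptor counts of the group stay the same. No measurement here accounts for the step.

On these data alone, it remains open whether the step follows the loss of the saturated ring, the arrival of the aromatic ring or the amine on that ring. An unsubstituted phenyl, a piperidin-2-yl or the opposite stereoisomer of pyrrolidin-2-yl at this place would each bear on that question.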